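The source may hold more compounds than are shown below. What is called first, only, known or untested is meant among the compounds shown, and "the series" means these compounds.

Three compounds that share one core and differ only in the group on the sulfonyl sulfur have been measured: compound 1 (`O=C(NCc1ccc(S(=O)(=O)c2cncc(C(F)(F)F)c2)cc1)N1Cc2ccncc2C1`), compound 2 (`O=C(NCc1ccc(S(=O)(=O)C2CCC(F)(F)CC2)cc1)N1Cc2ccncc2C1`) and compound 3 (`CCC(=O)N1CCC(S(=O)(=O)c2ccc(CNC(=O)N3Cc4ccncc4C3)cc2)CC1`). In an ADME assay on microsomes from liver (Homo sapiens) for pharmacokinetics, read by LC-MS, with a stated time of 60 min, tested at 1 uM (on this read-out lower numbers stand for slow clearance and higher numbers for fast clearance), compound 1 gives 13 mL/min/kg as its clearance, compound 2 gives 6 mL/min/kg on the same read-out and compound 3 gives 11 mL/min/kg in turn. Compound 3 therefore stands within the scatter of both others, as a 1.2-fold lower number from compound 1 to compound 3 (0.07 log units; within the scatter) and a 1.8-fold higher number from compound 2 to compound 3 (0.26 log units; within the scatter) show. Only a 2.2-fold lower number from compound 1 to compound 2 (0.34 log units; beyond the scatter) goes beyond the scatter, and that step is modest.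

Compound 4 (`O=C(NCc1ccc(S(=O)(=O)C2CCN(C3COC3)CC2)cc1)N1Cc2ccncc2C1`) differs from compound 3 by oxetan-3-yl in place of propanoyl on an amine nitrogen in a ring. Within the data shown here, none of the measured steps changes that nitrogen. They bear on it only indirectly, as a gauge of how far these compounds have moved with changes at the sulfonyl sulfur. No step beyond the scatter is therefore expected in this assay, and the estimated change is a 1.1-fold lower number from compound 3 to compound 4 (0.04 log units; within the scatter) with no firm direction. For compound 4 the estimate is 10 mL/min/kg with a range from 5 mL/min/kg to 20 mL/min/kg expected.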

Compound 4, clearance in the Homo sapiens assay: 10 mL/min/kg
For compound 4 middle estimate and measured number coincide at the digits printed; the range from low to high includes it.
By their numbers in the Homo sapiens assay, from the lowest: compounds 2, 4, 3 and 1 (each within the scatter of the next, the first and the last beyond it).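

In the Homo sapiens assay, compound 3 gives 11 mL/min/kg and compound 4 gives 10 mL/min/kg; the first change shown at the amine nitrogen in the ring, oxetan-3-yl in place of propanoyl, stays within the scatter (a 1.1-fold lower number from compound 3 to compound 4 (0.04 log units; within the scatter)), so at this position an open acyl group and a four-membered ring of the same heavy-atom count cannot be told apart on clearance. The 1-(oxetan-3-yl)piperidin-4-yl group on the sulfonyl sulfur also stays within the scatter of the 4,4-difluorocyclohexyl group (a 1.7-fold higher number from compound 2 to compound 4 (0.22 log units; within the scatter)) and of the 5-(trifluoromethyl)pyridin-3-yl group (a 1.3-fold lower number from compound 1 to compound 4 (0.11 log units; within the scatter)), which leaves the step between those two groups as the only one beyond it. In a physicochemical assay for solubility, in phosphate buffer, with a stated time of 24 h, at pH 7.4, tested at 100 uM (a lower number here means a less soluble compound, a higher number a more soluble compound), compound 3 gives 216000 nM and compound 4 gives 121000 nM, so the same nitrogen change also stays within the scatter (a 1.8-fold lower number from compound 3 to compound 4 (0.25 log units; within the scatter)), and nothing available explains why either read-out behaves this way.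

Only these two groups are shown on this nitrogen, so it remains open whether an unsubstituted amine, a longer acyl chain or a sulfonamide there would give a step beyond the scatter. Going by these compounds, it also remains open whether a larger ring, such as tetrahydropyran-4-yl, would read like oxetan-3-yl in either assay.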